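The source may hold more compounds than are shown below. What is called first, only, known or untested is meant among the compounds shown, and "the series" means these compounds.

Compound 1 `COC1=C(C)C(=O)/C(=C(O)/C=C/c2ccc(OC)cc2)C(=O)C1(C)C`: 5.6 ug/mL
Compound 2 `COC1=C(C)C(=O)/C(=C(O)/C=C/c2cccc(OC)c2)C(=O)C1(C)C`: 2.9 ug/mL
Compound 3 `COC1=C(C)C(=O)/C(=C(O)/C=C/c2ccccc2OC)C(=O)C1(C)C`: 4.1 ug/mL

In a functional assay on HCT-8 cells (Homo sapiens) for cytotoxicity (on this read-out lower numbers stand for an effect already at smaller amounts and higher numbers for an effect only at larger amounts of compound), compound 3 gives 4.1 ug/mL, within the scatter of both compound 1 and compound 2. Compound 4 `COC1=C(C)C(=O)/C(=C(O)/C=C/c2ccc(F)cc2)C(=O)C1(C)C` differs from compound 3 as follows: 4-fluorophenyl in place of 2-methoxyphenyl on a double-bonded chain carbon bound to a double-bonded chain carbon. The steps bearing on this change are those among the methoxyphenyl compounds: a 1.9-fold lower number from compound 1 to compound 2 (0.29 log units; within the scatter), a 1.4-fold lower number from compound 1 to compound 3 (0.14 log units; within the scatter) and a 1.4-fold higher number from compound 2 to compound 3 (0.15 log units; within the scatter). All three lie within the scatter. None of them brings in 4-fluorophenyl, so the series offers only indirect support. In this assay, no change beyond the scatter is expected, and the estimated step is a 1.0-fold lower number from compound 3 to compound 4 (0.01 log units; within the scatter). For compound 4 the estimated value is 4 ug/mL, with an expected range from 1.8 ug/mL to 9 ug/mL.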

Compound 4, concentration for half-maximal effect: 3.6 ug/mL
Compound 4: middle estimate off by 1.1-fold (0.05 log units), on the high side; the measured number falls inside the stated range.
By their numbers in this assay, from the lowest: compounds 2, 4, 3 and 1 (each within the scatter of the next).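

In this assay the series now holds a group other than methoxyphenyl on a double-bonded chain carbon bound to a double-bonded chain carbon, and 4-fluorophenyl stays within the scatter of all three methoxyphenyl compounds, with a 1.1-fold lower number from compound 3 to compound 4 (0.06 log units; within the scatter) and a 1.2-fold higher number from compound 2 to compound 4 (0.09 log units; within the scatter) as its steps. The cleanest comparison is fluoro in place of methoxy on an aromatic carbon, which gives a 1.6-fold lower number from compound 1 to compound 4 (0.19 log units; within the scatter) and so shows that replacing methoxy, not only moving it, leaves the number within the scatter. No measurement at hand explains this result.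

Going by these compounds, whether an amine or a carboxylic acid in place of the fluoro would move the number beyond the scatter remains open. The same holds for a longer chain between the shared core and the aromatic ring.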